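Methoxy to ethoxy on compound 3

The source may hold more compounds than are shown below. What is called first, only, known or untested is meant among the compounds shown, and "the series" means these compounds.

In a functional assay on MCF7 cells (Homo sapiens) for antiproliferative activity, read by MTT assay, with a stated time of 72 h (a higher number here means a weaker inhibitor, a lower number a stronger inhibitor), compound 1 `COc1cc(-n2ncnc2-c2ccc(C)cc2)cc(OC)c1OC` gives 540 nM. Compound 2 `COc1cc(-n2ncnc2-c2ccccc2)cc(OC)c1OC` gives > 10000 nM, which is a limit of the assay and not a number. Compound 3 `COc1ccccc1-c1ncnn1-c1cc(OC)c(OC)c(OC)c1` gives > 10000 nM, likewise a limit and not a number.

Compound 4 `CCOc1ccccc1-c1ncnn1-c1cc(OC)c(OC)c(OC)c1` takes compound 3 from methoxy to ethoxy, with methyl in place of hydrogen on a saturated chain carbon bound to an oxygen on an aromatic ring.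

Among the compounds with values here, no measured step covers this change directly. The nearest evidence is an at least 18-fold higher number from compound 1 to compound 3 (1.26 log units; beyond the scatter), a large step with 2-methoxyphenyl in place of 4-methylphenyl. With hydrogen in place of methyl on an aromatic carbon, the series shows an at least 18-fold higher number from compound 1 to compound 2 (1.26 log units; beyond the scatter), also large. With methoxy in place of hydrogen, it shows a step that the two limits leave unreadable from compound 2 to compound 3. Of the three measured compounds, only compound 1 gives a number, and compound 4 does not carry its 4-methylphenyl. Recovery from a single added methyl is therefore not expected, and no step beyond the scatter is expected in this assay. The expected step is a number no higher from compound 3 to compound 4 (the limit leaves the size open). The estimate for compound 4 is 10000 nM, with an expected range of 3000 nM to 30000 nM, and a further limit rather than a number is the likeliest report.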

Compound 4, half-maximal inhibitory concentration: > 10000 nM
Compound 4: a limit, no number; the forecaster's own chance of this, stated with the estimate: 75%; the middle value sits exactly at the limit.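

Compound 4 gives a limit of the assay and not a number in this assay, as do compound 2 and compound 3, so no new step among these three can be read: the limit of > 10000 nM in this assay, at which 3 of the 4 values shown sit.

The compounds shown leave open whether methoxy to ethoxy changes anything, since the true values of compound 3 and compound 4 remain unknown.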